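Ortho-halogen aroyl hydrazones: 2-fluorophenyl analogue of compound 2

The compounds below may be only part of what the source reports. "The series", "measured", "known", "first", "only" and "open" are said of these compounds alone.

Going by the values given here, compound 2 `CC(/C=N/Nc1ccc([N+](=O)[O-])cc1)=N\NC(=O)c1ccc(O)cc1` is the only member of the series with a numerical result: in a functional assay on cells (Splenocyte, Mus musculus, strain BALB/c) for inhibition, read by scintillation counting and thymidine incorporation, with a stated time of 72 h (on this read-out higher numbers stand for weaker inhibition and lower numbers for stronger inhibition), compound 2 gives 1510 nM. Compound 1 `CC(/C=N/Nc1ccc([N+](=O)[O-])cc1)=N\NC(=O)c1ccccc1Cl` reached only a limit in this assay, > 12000 nM. Among the compounds with values here, the one measured step, an at least 7.9-fold lower number from compound 1 to compound 2 (0.90 log units; beyond the scatter), is therefore bounded by the limit of > 12000 nM in this assay, at which 1 of the 2 values shown sits, and its true size is unknown beyond that bound.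

Compound 3 `CC(/C=N/Nc1ccc([N+](=O)[O-])cc1)=N\NC(=O)c1ccccc1F` differs from compound 2 by 2-fluorophenyl in place of 4-hydroxyphenyl on a carbonyl carbon. Within the data shown here, this step runs opposite to the measured one: a halogen returns at the same position on the aroyl ring, and the 4-hydroxyphenyl that accompanied the sole numerical value is lost. Among the measured compounds shown here, the only step that bears on it, an at least 7.9-fold lower number from compound 1 to compound 2 (0.90 log units; beyond the scatter), argues for a higher number in this assay, plausibly back toward the limit seen for compound 1.

Compound 3 is accordingly expected to give about 8000 nM in this assay, within roughly 2500 nM to 25000 nM, which is an estimated step of a 5.3-fold higher number from compound 2 to compound 3 (0.72 log units; beyond the scatter).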

Compound 3, half-maximal inhibitory concentration: > 12000 nM
Compound 3: no number, only a limit (the forecaster's own chance of this, stated with the estimate: 45%); middle value at least 1.5-fold (0.17 log units) from the limit.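

Replacing 4-hydroxyphenyl with 2-fluorophenyl on the carbonyl carbon gives an at least 7.9-fold higher number from compound 2 to compound 3 (0.90 log units; beyond the scatter) in this assay. Going by these compounds alone, the loss is therefore not confined to the 2-chlorophenyl group: compound 1 and compound 3 both stand as limits, so the step of fluoro in place of chloro cannot be read, and compound 2 remains the only compound with a number. The true size of the step from compound 2 stays bounded only: the limit of > 12000 nM in this assay, at which 2 of the 3 values shown sit.

The compounds shown do not separate the gain of the hydroxy group from the absence of a halogen, since each step changes both at once. Still open, as far as these compounds go, is whether a plain phenyl group, or a methoxy group, an amine or a carboxylic acid in place of the hydroxy group, would also give a number in this assay.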